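A few compounds are considered here, and "the series" means these few. Any claim that something is new, unique, unknown or untested is made for them only; others in the source may bear on it.

Compound 1 `CCOC(=O)C12C(=O)OCC=C1COC2c1cccc(Cl)c1` gives 28400 nM in a functional assay on A549 cells (Homo sapiens) for cytotoxicity, read by MTT assay; on this read-out lower numbers stand for stronger inhibition and higher numbers for weaker inhibition. Compound 2 `CCOC(=O)C12C(=O)OCC=C1COC2c1ccc(Cl)cc1` stands at the weak end of the numbers shown. In this assay compound 2 gives > 1000000 nM, which is a limit of the measurement rather than a number. Among the compounds with values here, the one measured step, an at least 35-fold higher number from compound 1 to compound 2 (1.54 log units; beyond the scatter), was large. Compound 3 `CCOC(=O)C12C(=O)OCC=C1COC2c1ccc(Cl)c(Cl)c1` carries the change (chloro in place of hydrogen on an aromatic carbon), so that it again holds the chloro group present in compound 1. Since that step was large, the step of an at least 6.6-fold lower number from compound 2 to compound 3 (0.82 log units; beyond the scatter) is expected to run toward a lower number. Compound 3 is estimated at 150000 nM, within 25000 nM to 1000000 nM.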

Compound 3, half-maximal inhibitory concentration: > 1000000 nM
Compound 3: only a limit was reported (the forecaster's own chance of this, stated with the estimate: 40%); middle value at least 6.6-fold (0.82 log units) from the limit.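

Chloro in place of hydrogen on an aromatic carbon, ortho to a chloro group, gave an at least 35-fold higher number from compound 1 to compound 3 (1.54 log units; beyond the scatter) in this assay. The chloro group of compound 1 is therefore still present in compound 3, yet this does not keep the value of compound 3 from reaching a limit rather than a number. The step from compound 2 to compound 3 cannot be read, because both values are limits: the limit of > 1000000 nM in this assay, at which 2 of the 3 values shown sit.

From the compounds shown here alone, whether a fluoro or a methoxy group on this aromatic carbon would give a readable value stays open. Going by these compounds, the true values of compound 2 and compound 3 also remain unknown.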